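A Pyrimidine Ring in Place of an Acetylphenyl Group

The compounds below may be only part of what the source reports. "The series", "measured", "known", "first", "only" and "open" are said of these compounds alone.

For the measured compounds named here, compound 2 `CC(=O)c1cccc(C2=NC(c3ccc(F)cc3)(c3ccc(F)cc3)CN2)c1` stands highest of the two numbers so far: in an assay on LM cells for displacement of a labelled ligand from Neuropeptide Y receptor type 5 (Homo sapiens) (on this read-out higher numbers stand for weaker inhibition and lower numbers for stronger inhibition), compound 2 gives 44 nM, while compound 1 `N#Cc1cccc(C2=NC(c3ccc(F)cc3)(c3ccc(F)cc3)CN2)c1` gives 2.7 nM. Compound 3 `Fc1ccc(C2(c3ccc(F)cc3)CNC(c3cncnc3)=N2)cc1` differs from compound 2 by pyrimidin-5-yl in place of 3-acetylphenyl on a carbon with a double bond to nitrogen. Going by the values given here, the only measured step, a 16-fold higher number from compound 1 to compound 2 (1.21 log units; beyond the scatter), altered a different group on the same carbon and bears on the present change only indirectly, showing that this position is sensitive. With no direct guide, a moderate but uncertain shift is expected, estimated as a 1.5-fold lower number from compound 2 to compound 3 (0.17 log units; within the scatter). Compound 3 is expected to give about 30 nM, within 5 nM to 200 nM.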

Compound 3, half-maximal inhibitory concentration: 47 nM
Beside the measured number, compound 3's estimate is 1.6-fold (0.19 log units) below it; measured number inside the range.
By their numbers in this assay, from the lowest: compound 1; then compounds 2 and 3 (each within the scatter of the next).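

In this assay, the smaller pyrimidin-5-yl ring, with no side group, matches the whole 3-acetylphenyl group on this carbon: a 1.1-fold higher number from compound 2 to compound 3 (0.03 log units; within the scatter). Against the nitrile-bearing ring it falls well short, a 17-fold higher number from compound 1 to compound 3 (1.24 log units; beyond the scatter), so among these three groups only 3-cyanophenyl stands apart. Nothing at hand explains either result. Still open, as far as these compounds go, is how an unsubstituted phenyl or a pyridin-3-yl ring would compare with pyrimidin-5-yl on this carbon. Also open, from the compounds shown here alone, is whether a nitrile on the pyrimidine ring would bring back the number of compound 1.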